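Sulfur-to-selenium swap on the chlorothiophene diacyl series

The compounds below may be only part of what the source reports. "The series", "measured", "known", "first", "only" and "open" are said of these compounds alone.

Three members of the series have been run in a functional assay on PC-3 cells (Homo sapiens) for cytotoxicity, read by MTT assay, with a stated time of 72 h; on this read-out higher numbers stand for weaker inhibition of growth and lower numbers for stronger inhibition of growth. Compound 1, `CS/C(=N\C(=O)c1sccc1Cl)NC(=O)c1sccc1Cl`, gives 57400 nM in this assay. Compound 2, `C[Se]/C(=N\C(=O)c1ccco1)NC(=O)c1ccco1`, gives 56700 nM in this assay, and compound 3, `O=C(/N=C(/NC(=O)c1csc([N+](=O)[O-])c1)[Se]Cc1ccccc1)c1csc([N+](=O)[O-])c1`, gives 69200 nM in this assay. Compound 1 stands with the other two: the gap to compound 2 and the gap to compound 3 both lie within the usual scatter, so none of the three can be set apart from the others on these numbers.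

The next compound to be measured is compound 4, `C[Se]/C(=N\C(=O)c1sccc1Cl)NC(=O)c1sccc1Cl`. It differs from compound 1 in one place: a group of 2 heavy atoms (1 carbon, 1 selenium; no ring) in place of a group of 2 heavy atoms (1 carbon, 1 sulfur; no ring), on a carbon with a double bond to nitrogen. For the measured compounds named here, the same exchange of sulfur for selenium at this position is the only thing separating compound 2 from the sulfur series in kind, and the value of compound 2 in this assay sits on top of that of compound 1. Going by the values given here, no measured pair shares this exact step, so the expected size rests on that resemblance alone. For compound 4 a step of a 1.0-fold lower number from compound 1 to compound 4 (0.02 log units; within the scatter) from compound 1 is expected, that is, none beyond the scatter. Compound 4 is therefore estimated at 55000 nM in this assay, with a range from 28000 nM to 110000 nM.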

Compound 4, concentration for total growth inhibition: 7030 nM
Compound 4: middle estimate off by 7.8-fold (0.89 log units), on the high side; measured number below the stated range.
By their numbers in this assay, from the lowest: compound 4; then compounds 2, 1 and 3 (each within the scatter of the next).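

In this assay, putting the group of 2 heavy atoms (1 carbon, 1 selenium) in place of methylsulfanyl, on a carbon with a double bond to nitrogen, gives an 8.2-fold lower number from compound 1 to compound 4 (0.91 log units; beyond the scatter), a step beyond the scatter with the two chlorothiophene acyl groups held constant. For the compounds shown here, this is the first matched pair, and it shows that the read-out at this position responds to the exchange of sulfur for selenium, something the earlier compounds could not show, as none of them differ in one place. Nothing measured here accounts for the size of this step.

Compound 2 and compound 3 also carry selenium at this carbon but have no sulfur partner among the compounds shown, so whether the step holds with their furan and nitrothiophene acyl groups cannot be read. Also open, as far as these compounds go, is how a longer chain such as ethyl, or an amine, would read at this same carbon with the chlorothiophene acyl groups kept, and whether either would give a lower number than compound 4 at 7030 nM.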